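Chloro for fluoro on the aryl ring of compound 2

The source may report more compounds than this note shows. Statements on the series, on what has been measured and on what is new or still open speak of the compounds shown alone.

The measured compounds:
compound 1, `Nc1nc(NCc2ccccc2)nc(-c2ccc(F)cc2CO)n1`, 4.58
compound 2, `Nc1nc(NCc2ccccc2)nc(-c2c(F)cccc2CO)n1`, 3.69
compound 3, `Nc1nc(NCc2ccccc2)nc(-c2ccc(Cl)cc2CO)n1`, 4.76

In a functional assay on cells for positive allosteric modulation of G-protein coupled receptor 68 (Homo sapiens), read by a luciferase reporter and cAMP accumulation, with a stated time of 30 min, at pH 6.8 and pH 8.3, in the presence of a further agent that is not named here (on this read-out higher numbers stand for higher potency (the scale is a negative logarithm) and lower numbers for lower potency), compound 3 gives 4.76 and compound 1 gives 4.58. The change between them, (chloro in place of fluoro on an aromatic carbon), made a step of a number 0.18 log units higher from compound 1 to compound 3 (within the scatter). Compound 2 stands lowest of the three in this assay; its gap to compound 1 and to compound 3 lies beyond the scatter in each case. How compound 2 differs from compound 1 is not broken down here: the two have the same atoms joined differently.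

Compound 4, `Nc1nc(NCc2ccccc2)nc(-c2c(Cl)cccc2CO)n1`, has not yet been measured in this assay. It differs from compound 2 by chloro in place of fluoro on an aromatic carbon. This is the same kind of change as that from compound 1 to compound 3, but not the same: in compound 2 the place is ortho to a large group and meta to a hydroxymethyl group, whereas in compound 1 it is meta to a hydroxymethyl group and para to a large group.

Among the measured compounds shown here, the only measured instance of this kind of change is the step of a number 0.18 log units higher from compound 1 to compound 3 (within the scatter), which lies within the scatter. On that basis, the step from compound 2 to compound 4 in this assay is expected to be small, about a number 0.21 log units higher from compound 2 to compound 4 (within the scatter), with the different surroundings of the place leaving room for a somewhat different outcome. Compound 4 is therefore estimated at 3.9 in this assay, expected to lie between 3.3 and 4.5.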

Compound 4, negative logarithm of the antagonist equilibrium constant: 4.43
Compound 4: middle estimate off by 0.53 log units, on the low side, and the stated range covers the measured number.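

In this assay, chloro in place of fluoro on an aromatic carbon gave a number 0.74 log units higher from compound 2 to compound 4 (beyond the scatter), so on this core the change moved the number by more than the usual scatter of repeated measurements. The size of the step therefore did not carry over from one core to the other, and a step read on one core was a poor guide to the step on the other: the same change on two cores in this assay, a number 0.18 log units higher (within the scatter) from compound 1 to compound 3 and a number 0.74 log units higher (beyond the scatter) from compound 2 to compound 4, 0.56 log units apart, beyond the scatter of two such steps This does not show why the two steps differ, since the pairs differ in where the halogen sits, ortho to a large group in compound 4 and para to one in compound 3, and two pairs cannot separate that placement from anything else, nor say how the change would behave on any further core.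

The compounds shown leave open whether a bromo, a methyl or a nitrile at the same place would give a step closer to the larger or to the smaller one. They also leave open whether the step would survive if the hydroxymethyl group gave way to a longer chain, an amine or a carboxylic acid.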